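The source may report more compounds than this note shows. Statements on the series, on what has been measured and on what is new or still open speak of the compounds shown alone.

Measured so far in an assay on HeLa cells for inhibition of sphingosine-1-phosphate transporter SPNS2 (Mus musculus), read by LC-MS, tested at 2 uM; on this read-out lower numbers stand for less inhibition and higher numbers for more inhibition at the one concentration tested (going by the name of the read-out):
- compound 1, `CCCCCCCCCCc1ccc(-c2noc(C3CNC3)n2)cc1`: 65%
- compound 2, `CCCCCCCCCCc1ccc(-c2noc(CN)n2)cc1`: 62%
- compound 3, `CCCCCCCCCCc1ccc(-c2noc([C@H]3CCC[C@@H](N)C3)n2)cc1`: 29%

Compound 3 stands lowest of the three. Its nearest neighbour is compound 2, and the step of a number 33 percentage points lower from compound 2 to compound 3 (beyond the scatter) is beyond the scatter; the step of a number 36 percentage points lower from compound 1 to compound 3 (beyond the scatter) is likewise beyond the scatter. Between compound 1 and compound 2 the step of a number 3 percentage points lower from compound 1 to compound 2 (within the scatter) lies within the scatter, so the two ring-free and small-ring amines sit together and the 3-aminocyclohexyl compound sits apart from them.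

Compound 4, `CCCCCCCCCCc1ccc(-c2noc([C@@H](N)CCN)n2)cc1`, differs from compound 3 in one place: 1,3-diaminopropyl in place of 3-aminocyclohexyl on an aromatic carbon.

Both large steps on record run toward the 3-aminocyclohexyl group; the change to compound 4 runs away from it, to an open chain with an amine at each end. Compound 2, the chain-bearing neighbour, gives 62%. A rise in this assay is therefore expected, of roughly the size of the earlier drops reversed: a number 26 percentage points higher from compound 3 to compound 4 (beyond the scatter). For compound 4 the estimate is 55%, with a range from 35% to 75%.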

Compound 4, a percentage reported as inhibition, at one concentration (the size of the read-out at that concentration, not a potency): 14%
Compound 4: middle estimate off by 41 percentage points, on the high side; the whole stated range lies above it.
By their numbers in this assay, from the lowest: compound 4; then compound 3; then compounds 2 and 1 (each within the scatter of the next).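

In this assay, leaving the ring for an open chain does not recover the number: 1,3-diaminopropyl in place of 3-aminocyclohexyl gives a number 15 percentage points lower from compound 3 to compound 4 (beyond the scatter), even though the entering group has fewer heavy atoms, so heavy-atom count alone does not order these groups at this position. Adding 2-aminoethyl to the saturated chain carbon of the aminomethyl group gives a number 48 percentage points lower from compound 2 to compound 4 (beyond the scatter), and 1,3-diaminopropyl in place of azetidin-3-yl gives a number 51 percentage points lower from compound 1 to compound 4 (beyond the scatter), so a second amine on a branched chain brings no gain here. Nothing measured on these compounds accounts for the drop.

The compounds shown do not separate the branch from the second amine, which a plain ethyl group on the same carbon would address. On these data alone, the opposite configuration at that carbon also remains open.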